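Pyrazoline-pyridazine analogues: a planned trifluoromethyl swap

The compounds below may be only part of what the source reports. "The series", "measured", "known", "first", "only" and "open" are said of these compounds alone.

The measured compounds:

Compound 1 `Fc1ccc(C2CC(c3ccc(Cl)cc3)=NN2c2ccc(-c3ccccc3)nn2)cc1`: in a functional assay on A549 cells (Homo sapiens) for antiproliferative activity, read by MTT assay, with a stated time of 24 h (on this read-out higher numbers stand for weaker inhibition and lower numbers for stronger inhibition), compound 1 gives > 100000 nM, which is a limit of the assay and not a number.
Compound 2 `FC(F)(F)c1ccc(C2CC(c3ccc(Cl)cc3)=NN2c2ccc(-c3ccccc3)nn2)cc1`: in this assay compound 2 gives > 100000 nM, again a limit.
Compound 3 `COc1ccc(C2=NN(c3ccc(-c4ccccc4)nn3)C(c3ccc(F)cc3)C2)cc1`: in this assay compound 3 gives > 100000 nM, also a limit.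

All three measured values sit at the limit of > 100000 nM in this assay, at which 3 of the 3 values shown sit, so none of them is a number that can be compared with another. The change from compound 1 to compound 2 is trifluoromethyl in place of fluoro on an aromatic carbon; its step, a step that the two limits leave unreadable from compound 1 to compound 2, cannot be read, since both ends are limits. The change from compound 1 to compound 3 is methoxy in place of chloro on an aromatic carbon; this step, a step that the two limits leave unreadable from compound 1 to compound 3, is equally unreadable for the same reason.

Compound 4 `COc1ccc(C2=NN(c3ccc(-c4ccccc4)nn3)C(c3ccc(C(F)(F)F)cc3)C2)cc1` has not yet been measured. It differs from compound 3 by trifluoromethyl in place of fluoro on an aromatic carbon. The place of this change, as it is described, matches word for word the place of the change from compound 1 to compound 2, so the two changes are the same. That earlier change left compound 2 at a limit where compound 1 had already been at a limit, and compound 3 starts from a limit as well. The step from compound 3 to compound 4 in this assay is therefore expected to be a step that the limit leaves unreadable from compound 3 to compound 4, which rests on the limit seen for compound 2, > 100000 nM. For compound 4 in this assay the expected value is 150000 nM, with a limit rather than a number the most likely outcome.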

Compound 4, half-maximal inhibitory concentration: > 100000 nM
Compound 4: no number, only a limit; the forecaster's own chance of this, stated with the estimate: 90%; the middle value lies beyond the limit too.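

Compound 4 gives a limit and not a number, as do compound 2 and compound 3, so neither step to compound 4 can be read, and no size can be given for either change. All the compounds shown sit at the same limit in this assay: the limit of > 100000 nM in this assay, at which 4 of the 4 values shown sit.

The compounds shown leave open whether any change on the shared core would give a measurable value in this assay.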